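This account rests on a few compounds, and the source may have more. Where it says the series, first, only, none or still open, it means among the compounds named here.

Measured in a functional assay on MCF7 cells (Homo sapiens) for cytotoxicity, read by MTT assay and propidium iodide staining, with a stated time of 24 h; on this read-out higher numbers stand for weaker inhibition and lower numbers for stronger inhibition:
- Compound 1 `O=C(CSc1nnc(-c2ccccc2F)o1)c1ccccc1`: 260 nM
- Compound 2 `Nc1cc(-c2nnc(SCC(=O)c3ccccc3)o2)ccn1`: 140 nM
- Compound 3 `O=C(CSc1nnc(-c2ccnc(Cl)c2)o1)c1ccccc1`: 1290 nM

Compound 2 cannot be told apart from compound 1, with a 1.9-fold lower number from compound 1 to compound 2 (0.27 log units; within the scatter). Compound 3 stands apart from both, with a 9.2-fold higher number from compound 2 to compound 3 (0.96 log units; beyond the scatter) and a 5.0-fold higher number from compound 1 to compound 3 (0.70 log units; beyond the scatter).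

Compound 4 `Nc1cc(-c2nnc(SCC(=O)c3ccc(Br)cc3)o2)ccn1` is compound 2 with bromo in place of hydrogen on an aromatic carbon, taking phenyl to 4-bromophenyl: bromo in place of hydrogen on an aromatic carbon. Among the measured compounds shown here, none of the measured steps touches this phenyl. All three change the other aromatic group, so they show how far a single swap can move the number in this series, not what bromo does here. On these data alone, without a direct guide, no step beyond the scatter is expected in this assay, and either direction remains open. The expected step is no change at the digits printed from compound 2 to compound 4 (within the scatter). The estimated value for compound 4 is 140 nM, with an expected range of 45 nM to 450 nM.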

Compound 4, half-maximal inhibitory concentration: 200 nM
Estimate against measurement, compound 4: 1.4-fold (0.15 log units) below; measured number inside the range.
By their numbers in this assay, from the lowest: compounds 2, 4 and 1 (each within the scatter of the next); then compound 3.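

In this assay, bromo in place of hydrogen, taking phenyl to 4-bromophenyl, gives a 1.4-fold higher number from compound 2 to compound 4 (0.15 log units; within the scatter), so this added heavy atom leaves the number within the scatter. Among the compounds shown here, the earlier steps all changed the other aromatic group, so this is the first direct reading at this phenyl. Nothing measured here offers an explanation for this result.

A single bromo says little about the position as a whole. On these data alone, whether a methoxy group, an amine or a carboxylic acid in the same place would also leave the number within the scatter remains open.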